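The source may hold more compounds than are shown below. What is called first, only, known or untested is meant among the compounds shown, and "the series" means these compounds.

Compound 1 `CC(/C=N/Nc1ccc([N+](=O)[O-])cc1)=N\NC(=O)c1ccc(N)cc1`: in a functional assay on cells (Splenocyte, Mus musculus, strain BALB/c) for inhibition, read by scintillation counting and thymidine incorporation, with a stated time of 72 h (a lower number here means a stronger inhibitor, a higher number a weaker inhibitor), a limit of > 12000 nM.
Compound 2 `CC(/C=N/Nc1ccc([N+](=O)[O-])cc1)=N\NC(=O)c1ccc(C(C)(C)C)cc1`: in this assay a limit of > 12000 nM.

Compound 1 therefore stands only at a limit, and both values shown sit there (the limit of > 12000 nM in this assay, at which 2 of the 2 values shown sit). Among the measured compounds shown here, the one measured step, a step that the two limits leave unreadable from compound 1 to compound 2, is unreadable, so no change on that aromatic carbon has yet given a number. Compound 3 `CC(/C=N/Nc1ccc([N+](=O)[O-])cc1)=N\NC(=O)c1cccc(C)c1` differs from compound 1 by 3-methylphenyl in place of 4-aminophenyl on a carbonyl carbon. For the measured compounds named here, no measured step bears on this change, and nothing suggests it would move the value far from where compound 1 sits. Compound 3 is expected to give about 15000 nM, within 4000 nM to 60000 nM, most likely again as a limit. The expected step is a step that the limit leaves unreadable from compound 1 to compound 3.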

Compound 3, half-maximal inhibitory concentration: > 12000 nM
Compound 3 was reported as a limit; the forecaster's own chance of this, stated with the estimate: 70%; the middle value does not contradict the limit.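

Compound 1 and compound 3 are both reported only as limits in this assay, so the step between them cannot be read. The compounds shown leave open whether any change on the carbonyl carbon would give a measurable value: the limit of > 12000 nM in this assay, at which 3 of the 3 values shown sit.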